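This account rests on a few compounds, and the source may have more. Where it says the series, first, only, none or still open, it means among the compounds named here.

For the measured compounds named here, in an assay on HEK293 cells for agonist activity at transient receptor potential cation channel subfamily M member 8 (Homo sapiens), read by fluorescence and calcium flux, with a stated time of 15 min (on this read-out lower numbers stand for an effect already at smaller amounts and higher numbers for an effect only at larger amounts of compound), compound 1 `Cc1ccc(OCC(=O)N(Cc2cccs2)c2ccnn2C)cc1` gives 422 nM, the second highest of the three numbers measured so far. Compound 2 `CCN(Cc1ccccc1)C(=O)COc1ccc(C)cc1` lies nearest to it with 1880 nM, while compound 3 `O=C(COc1ccc2c(c1)CCC2)N(Cc1cccs1)c1ccn[nH]1` stands far away at the low end with 0.001 nM. Compound 4 `COCCN(Cc1cccs1)C(=O)COc1ccc(C)cc1` has not yet been measured in this assay. It differs from compound 1 in one place: 2-methoxyethyl in place of 1-methyl-1H-pyrazol-5-yl on an amide-type nitrogen. Going by the values given here, no measured pair shows this change directly, so any expectation rests on the spread already seen. The step from compound 1 to compound 4 is expected to be a 2.6-fold higher number from compound 1 to compound 4 (0.42 log units; beyond the scatter), a rise beyond the scatter, because compound 2, which also carries an open chain on the amide-type nitrogen, gives 1880 nM. Compound 4 is therefore estimated at 1100 nM, within a range from 300 nM to 4000 nM.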

Compound 4, half-maximal effective concentration: 400 nM
The estimate for compound 4 lay 2.8-fold (0.44 log units) above the measured number, within the range that was stated.
By their numbers in this assay, from the lowest: compound 3; then compounds 4 and 1 (each within the scatter of the next); then compound 2.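

In this assay, putting 2-methoxyethyl in place of 1-methyl-1H-pyrazol-5-yl on the amide-type nitrogen gives a 1.1-fold lower number from compound 1 to compound 4 (0.02 log units; within the scatter). On the core of compound 1, then, the five-membered aromatic ring at this position can give way to a chain with no ring without a change beyond the scatter. Nothing available explains this match. Still open, as far as these compounds go, is whether a longer ether chain, a chain ending in an amine or one ending in a carboxylic acid would fit this nitrogen equally well.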